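Swapping the aryl amide for a cyclopropyl amide

The source may hold more compounds than are shown below. What is called first, only, known or untested is meant among the compounds shown, and "the series" means these compounds.

Measured compounds:
compound 1, `CN1CCC(C(=O)N2Cc3c(NC(=O)Nc4cccc(F)c4)n[nH]c3C2(C)C)CC1`, 350 nM
compound 2, `CN1CCC(C(=O)N2Cc3c(NC(=O)c4ccccc4)n[nH]c3C2(C)C)CC1`, 160 nM
compound 3, `CN1CCC(C(=O)N2Cc3c(NC(=O)c4cc(F)cc(F)c4)n[nH]c3C2(C)C)CC1`, 130 nM

All three numbers come from a functional assay on A2780 cells (Homo sapiens) for antiproliferative activity, read by fluorescence, with a stated time of 72 h; a lower number here means a stronger inhibitor, a higher number a weaker inhibitor. Compound 3 has the lowest number of the three; its nearest neighbour is compound 2, and the pair sits within the scatter, as the step of a 1.2-fold lower number from compound 2 to compound 3 (0.09 log units; within the scatter) shows. Compound 1 is further away: a 2.7-fold lower number from compound 1 to compound 3 (0.43 log units; beyond the scatter) and a 2.2-fold lower number from compound 1 to compound 2 (0.34 log units; beyond the scatter) are both modest but beyond the scatter.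

Compound 4, `CN1CCC(C(=O)N2Cc3c(NC(=O)C4CC4)n[nH]c3C2(C)C)CC1`, has not yet been measured in this assay. It differs from compound 3 in one place: cyclopropyl in place of 3,5-difluorophenyl on a carbonyl carbon. Within the data shown here, none of the measured steps exchanges an aromatic ring for a non-aromatic one; the only step on this carbonyl carbon among amides, a 1.2-fold lower number from compound 2 to compound 3 (0.09 log units; within the scatter), merely shows that the two fluorines on the phenyl add little. Among the measured compounds shown here, a rise in the number is therefore expected, but its size rests on no direct precedent. Compound 4 is estimated at 400 nM, within 100 nM to 1600 nM, meaning an expected step of a 3.1-fold higher number from compound 3 to compound 4 (0.49 log units; beyond the scatter).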

Compound 4, half-maximal inhibitory concentration: 1420 nM
Compound 4: middle estimate off by 3.6-fold (0.55 log units), on the low side, and the stated range covers the measured number.
By their numbers in this assay, from the lowest: compounds 3 and 2 (each within the scatter of the next); then compound 1; then compound 4.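

In this assay, this carbonyl carbon proves far more sensitive to losing the aromatic ring than the fluorines on that ring had suggested: the change brings an 11-fold higher number from compound 3 to compound 4 (1.04 log units; beyond the scatter) and an 8.9-fold higher number from compound 2 to compound 4 (0.95 log units; beyond the scatter), while removing both fluorines had left the number within the scatter. The (3-fluorophenyl)amino group also gives a lower number than cyclopropyl, with a 4.1-fold higher number from compound 1 to compound 4 (0.61 log units; beyond the scatter), so all three aryl-bearing groups shown outperform this small carbocycle, even though compound 1 was the weakest of the earlier set. Nothing available explains this loss of activity.

The compounds shown do not separate the loss of aromaticity from the loss of heavy atoms, as cyclopropyl differs from the phenyl groups in both. Going by these compounds, how a cyclohexyl group, a pyridyl ring or a benzyl group would behave on this carbonyl carbon remains open.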